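A few compounds are considered here, and "the series" means these few. Any claim that something is new, unique, unknown or untested is made for them only; others in the source may bear on it.

Measured so far in a functional assay on RKO cells (Homo sapiens) for cytotoxicity, read by resazurin assay, with a stated time of 72 h; a higher number here means a weaker inhibitor, a lower number a stronger inhibitor:
- compound 1 `COc1ccc(Nc2nc(-n3c(C)nc4ccccc43)cs2)cc1` gives 25 nM
- compound 3 `Cc1nc2ccccc2n1-c1csc(Nc2ccccc2)n1` gives 40000 nM
- compound 2 `c1ccc(Nc2nc(-n3ccnc3)cs2)cc1` gives > 100000 nM, which is a limit of this assay and not a number.

Compound 3 to compound 1 is methoxy in place of hydrogen on an aromatic carbon, and this assay shows a 1600-fold lower number from compound 3 to compound 1 (3.20 log units; beyond the scatter). Compound 2 stands at the limit of > 100000 nM in this assay, at which 1 of the 3 values shown sits. The difference between the core of compound 2 and the core of compound 3 is not broken down here.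

Compound 4 `COc1ccc(Nc2nc(-n3ccnc3)cs2)cc1` is the same change made from compound 2: methoxy in place of hydrogen on an aromatic carbon. From the compounds shown here alone, the step from compound 2 to compound 4 in this assay is expected to be an at least 50-fold lower number from compound 2 to compound 4 (1.69 log units; beyond the scatter), which rests on a 1600-fold lower number from compound 3 to compound 1 (3.20 log units; beyond the scatter), tempered since compound 2 gives only a limit and the true starting point is unknown. Compound 4 is therefore expected near 2000 nM, within 150 nM to 40000 nM.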

Compound 4, half-maximal inhibitory concentration: > 100000 nM
Compound 4: a limit, no number; the forecaster's own chance of this, stated with the estimate: 20%; at least 50-fold (1.69 log units) between middle value and limit.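

No step can be read from compound 2 to compound 4, since both stand at one limit: the limit of > 100000 nM in this assay, at which 2 of the 4 values shown sit. The compounds shown leave open whether methoxy in place of hydrogen on an aromatic carbon changes the number at all on the core of compound 2.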